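Replacing the benzyl arm of compound 1 with an ester chain

A few compounds are considered here, and "the series" means these few. Any claim that something is new, unique, unknown or untested is made for them only; others in the source may bear on it.

Compound 1 `O=[N+]([O-])c1ccc(-c2cn(Cc3ccccc3)nn2)cc1` is the reference of the set. Among the measured compounds shown here, in a functional assay on B16 cells (Mus musculus) for cytotoxicity, read by MTT assay, with a stated time of 48 h (a lower number here means a stronger inhibitor, a higher number a weaker inhibitor), compound 1 gives 5120 nM, the only plain number among the three values shown. Compound 2 `Cc1ccc(-c2cn(Cc3ccccc3)nn2)cc1` carries methyl in place of nitro on an aromatic carbon; in this assay compound 2 gives > 100000 nM, which is a limit of the assay rather than a number. Compound 3 `COc1ccc(-c2cn(Cc3ccccc3)nn2)cc1` carries methoxy in place of nitro on an aromatic carbon; in this assay compound 3 gives > 100000 nM, again a limit. Both steps away from compound 1 are large: an at least 19-fold higher number from compound 1 to compound 2 (1.29 log units; beyond the scatter) and an at least 19-fold higher number from compound 1 to compound 3 (1.29 log units; beyond the scatter), each ending at the limit of > 100000 nM in this assay, at which 2 of the 3 values shown sit. The remaining step cannot be read: a step that the two limits leave unreadable from compound 2 to compound 3.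

Compound 4 `CCOC(=O)Cn1cc(-c2ccc([N+](=O)[O-])cc2)nn1` is not yet measured. It differs from compound 1 elsewhere: ethoxycarbonyl in place of phenyl on a saturated chain carbon bound to an aromatic nitrogen. The nitro group is kept. For the measured compounds named here, no measured step touches the saturated chain carbon bound to the aromatic nitrogen, so none gives a direct guide to the size or direction of this change. Compound 4 is therefore expected to stay near compound 1, the expected step being a 1.6-fold higher number from compound 1 to compound 4 (0.19 log units; within the scatter), held with a wide range. Compound 4 is estimated at 8000 nM, between 2000 nM and 40000 nM.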

Compound 4, half-maximal inhibitory concentration: > 100000 nM
Compound 4 ended at the assay's limit; the forecaster's own chance of this, stated with the estimate: 20%; at least 12-fold (1.09 log units) between middle value and limit.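

The saturated chain carbon bound to an aromatic nitrogen is not a free position in this series: with the nitro group kept, ethoxycarbonyl in place of phenyl gives an at least 19-fold higher number from compound 1 to compound 4 (1.29 log units; beyond the scatter). In this assay, from the compounds shown here alone, compound 4 gives > 100000 nM, which is a limit of the assay and not a number, so the full size of this step stays unknown. The earlier steps singled out only the nitro group, but keeping it does not by itself hold a readable value, and compound 1 remains the only plain number in the set: the limit of > 100000 nM in this assay, at which 3 of the 4 values shown sit.

Open, going by these compounds, is whether a carboxylic acid, an amine or a longer chain in place of ethoxycarbonyl, or a substituted phenyl in place of phenyl, would give a readable value at this position. Steps between the compounds that sit at the limit cannot be read.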